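From 4-chlorophenyl to 3-nitrophenyl: series notes

The source may report more compounds than this note shows. Statements on the series, on what has been measured and on what is new or still open speak of the compounds shown alone.

Values in a functional assay on PANC-1 cells (Homo sapiens) for antiproliferative activity, read by CCK-8 assay, with a stated time of 72 h; on this read-out lower numbers stand for stronger inhibition and higher numbers for weaker inhibition:
- compound 1 `Cc1cc(Nc2cc(N3CCN(C)CC3)nc(Nc3ccc(S(N)(=O)=O)cc3)n2)n[nH]1`: 8760 nM
- compound 2 `Cc1cc(Nc2cc(N3CCN(C)CC3)nc(Nc3ccc([N+](=O)[O-])cc3)n2)n[nH]1`: 442 nM
- compound 3 `Cc1cc(Nc2cc(N3CCN(C)CC3)nc(Nc3ccc(Cl)cc3)n2)n[nH]1`: 455 nM

Compound 3 stands at 455 nM, within the scatter of compound 2 and far lower than compound 1. Next is compound 4 `Cc1cc(Nc2cc(N3CCN(C)CC3)nc(Nc3cccc([N+](=O)[O-])c3)n2)n[nH]1`, with 3-nitrophenyl in place of 4-chlorophenyl on a nitrogen on an aromatic ring. For the measured compounds named here, three measured steps bear on this. The large steps of a 20-fold lower number from compound 1 to compound 2 (1.30 log units; beyond the scatter) and a 19-fold lower number from compound 1 to compound 3 (1.28 log units; beyond the scatter) both remove sulfamoyl, which is not involved here. Going by the values given here, the closest precedent is a 1.0-fold higher number from compound 2 to compound 3 (0.01 log units; within the scatter), within the scatter. Among the compounds with values here, no measured compound carries 3-nitrophenyl, so that placement remains untested. No step beyond the scatter is expected in this assay, and no direction is firmly expected. The expected change is a 1.3-fold higher number from compound 3 to compound 4 (0.12 log units; within the scatter). For compound 4 the estimate is 600 nM, with an expected range of 220 nM to 1800 nM.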

Compound 4, half-maximal inhibitory concentration: 457 nM
Compound 4: the middle estimate sits 1.3-fold (0.12 log units) above what was measured, and the stated range covers the measured number.
By their numbers in this assay, from the lowest: compounds 2, 3 and 4 (each within the scatter of the next); then compound 1.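

In this assay there is a 1.0-fold higher number from compound 2 to compound 4 (0.01 log units; within the scatter) with 3-nitrophenyl in place of 4-nitrophenyl, so this placement of the nitro group shows no step beyond the scatter. Likewise, a 1.0-fold higher number from compound 3 to compound 4 (0.00 log units; within the scatter) with 3-nitrophenyl in place of 4-chlorophenyl leaves the two indistinguishable, while a 19-fold lower number from compound 1 to compound 4 (1.28 log units; beyond the scatter) with 3-nitrophenyl in place of 4-sulfamoylphenyl shows that the large gap to compound 1 holds for this placement too. No measured evidence bears on the cause of these results.

Open, going by these compounds, is whether an amine, a carboxylic acid or a methoxy group on this ring would stay level with compounds 2, 3 and 4 or fall toward compound 1.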